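Ethoxycarbonyl to Carbamoyl: Estimating Compound 4

The source may hold more compounds than are shown below. What is called first, only, known or untested is meant among the compounds shown, and "the series" means these compounds.

Compound 1, `CCOC(=O)c1sc(-c2cccc(NC(=O)c3ccccc3)c2)nc1Nc1ccc(N2CCN(C)CC2)cc1`, gives 42% in a functional assay on Raji cells (Homo sapiens) for antiproliferative activity, read by CCK-8 assay, with a stated time of 72 h, tested at 40 uM; a lower number here means less inhibition, a higher number more inhibition at the concentration tested (going by the name of the read-out).
Compound 2, `CCOC(=O)c1sc(-c2cccc(NC(=O)c3ccc(Cl)cc3)c2)nc1Nc1ccc(N2CCN(C)CC2)cc1`, gives 24.3% in this assay.
Compound 3, `CCOC(=O)c1sc(-c2cccc(NC(=O)[C@H]3CC[C@H](C)CC3)c2)nc1Nc1ccc(N2CCN(C)CC2)cc1`, gives 26.1% in this assay.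

Compound 3 stands second highest of the three numbers. Its nearest neighbour is compound 2, and the step of a number 1.8 percentage points higher from compound 2 to compound 3 (within the scatter) lies within the scatter, so the two cannot be ordered. Its furthest neighbour is compound 1, separated by a number 15.9 percentage points lower from compound 1 to compound 3 (beyond the scatter).

Compound 4, `CN1CCN(c2ccc(Nc3nc(-c4cccc(NC(=O)[C@H]5CC[C@H](C)CC5)c4)sc3C(N)=O)cc2)CC1`, has not yet been measured in this assay. It differs from compound 3 in one place: amino in place of ethoxy on a carbonyl carbon. The change sits on a carbonyl carbon whose other neighbour is an aromatic carbon; cut one bond further out it reads ethoxycarbonyl to carbamoyl.

Among the compounds with values here, none of the measured steps touches this position. Both a number 17.7 percentage points lower from compound 1 to compound 2 (beyond the scatter) and a number 15.9 percentage points lower from compound 1 to compound 3 (beyond the scatter) alter the group on the other carbonyl carbon of the shared core, and a number 1.8 percentage points higher from compound 2 to compound 3 (within the scatter) compares two such groups. The numbers therefore give no direct guide to replacing ethoxy with amino, and the expectation is of no step beyond the scatter, a number 1.9 percentage points higher from compound 3 to compound 4 (within the scatter).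

Compound 4 is estimated at 28%, with a range from 12% to 45%.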

Compound 4, a percentage reported as inhibition, at one concentration (the size of the read-out at that concentration, not a potency): 22.4%
Estimate against measurement, compound 4: 5.6 percentage points above; low and high end bracket the measured number.
By their numbers in this assay, from the lowest: compounds 4, 2 and 3 (each within the scatter of the next); then compound 1.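

Within the data shown here, the measurement gives the first reading at this position: in this assay, putting amino in place of ethoxy on a carbonyl carbon gives a number 3.7 percentage points lower from compound 3 to compound 4 (within the scatter), whereas the earlier steps changed only the group on the other carbonyl carbon. With the 4-methylcyclohexyl group held constant, ethoxy with its 3 heavy atoms gives way to amino with 1 heavy atom and 1 hydrogen-bond donor, and no step beyond the scatter follows, so this single pair shows that the ethoxycarbonyl group can be exchanged for carbamoyl without a detectable shift in the read-out. No measured property of these compounds bears on this result.

The compounds shown leave open whether amino would give a step of the same size alongside the phenyl group of compound 1, since the exchange is seen only with the 4-methylcyclohexyl group. They also leave open what a carboxylic acid, a methylamino group or a longer chain such as propoxy would give on this carbonyl carbon.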